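The source may hold more compounds than are shown below. What is called first, only, known or untested is meant among the compounds shown, and "the series" means these compounds.

Of the compounds shown here, three sharing one core have been tested in a functional assay on HepG2 cells (Homo sapiens) for antiproliferative activity, read by MTT assay, with a stated time of 48 h; on this read-out lower numbers stand for stronger inhibition and higher numbers for weaker inhibition. Compound 1 `CCn1c(C(=O)N(CCC#N)CCC#N)ccc1C(CC)(CC)c1ccc(OCCC(O)(CC)CC)c(C)c1` gives 46300 nM. Compound 2 `C#CCCOC(=O)c1ccc(C(CC)(CC)c2ccc(OCCC(O)(CC)CC)c(C)c2)n1CC` gives > 50000 nM, which is a limit of the assay and not a number. Compound 3 `CCOC(=O)CN(C)C(=O)c1ccc(C(CC)(CC)c2ccc(OCCC(O)(CC)CC)c(C)c2)n1CC` gives 25300 nM, within the usual scatter of compound 1, so neither of these two can be ranked over the other.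

Compound 4 `CCC(C)C(NC(=O)c1ccc(C(CC)(CC)c2ccc(OCCC(O)(CC)CC)c(C)c2)n1CC)C(=O)O` carries (1-carboxy-2-methylbutyl)amino in place of ((ethoxycarbonyl)methyl)(methyl)amino on a carbonyl carbon. The three tested compounds also differ from one another at this carbonyl carbon, which gives the closest guide. Among the compounds with values here, the one step between two true numbers is a 1.8-fold lower number from compound 1 to compound 3 (0.26 log units; within the scatter). The other two, an at least 1.9-fold lower number from compound 2 to compound 3 (0.29 log units; that floor lies within the scatter) and an at least 1.0-fold higher number from compound 1 to compound 2 (0.03 log units; that floor lies within the scatter), rest on a limit. None of the tested compounds carries a carboxy group, so the guide is imperfect.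

Given the size of those steps, no change beyond the scatter is expected in this assay. The estimated step is a 1.2-fold higher number from compound 3 to compound 4 (0.07 log units; within the scatter). For compound 4 the estimate is 30000 nM, with an expected range from 12000 nM to 50000 nM.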

Compound 4, half-maximal inhibitory concentration: 2620 nM
Compound 4: middle estimate off by 11-fold (1.06 log units), on the high side, and the stated range ends above it.
By their numbers in this assay, from the lowest: compound 4; then compounds 3 and 1 (each within the scatter of the next). At a limit, above all of these: compound 2.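

In this assay, the change at this carbonyl carbon from ((ethoxycarbonyl)methyl)(methyl)amino to (1-carboxy-2-methylbutyl)amino moves the read-out beyond the scatter (a 9.7-fold lower number from compound 3 to compound 4 (0.98 log units; beyond the scatter)), and compound 4 also stands clear of compound 1 (an 18-fold lower number from compound 1 to compound 4 (1.25 log units; beyond the scatter)). Among the true numbers, only the earlier step within the scatter had been seen, whereas this position can now be seen to shift antiproliferative activity on this read-out. Compound 2 gives a limit and not a number, which makes its step (an at least 19-fold lower number from compound 2 to compound 4 (1.28 log units; beyond the scatter)) only a floor: the limit of > 50000 nM in this assay, at which 1 of the 4 values shown sits.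

The carboxy group, the amide hydrogen and the branched chain all enter together in compound 4, so the compounds shown cannot separate their contributions. A methyl ester of the same chain, or a shorter carboxylic acid such as (carboxymethyl)amino, would help to show which part carries the change.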